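The source may report more compounds than this note shows. Statements on the series, on what has been measured and on what is new or still open speak of the compounds shown alone.

Measured so far in a functional assay (Mus musculus) for inhibition, with a stated time of 5 days; a lower number here means a stronger inhibitor, a higher number a weaker inhibitor:
Compound 1 `O=Cc1cn(-c2ccc(O)cc2)nc1-c1ccc(O)c(O)c1` gives 12000 nM.
Compound 2 `O=C(O)/C=C/c1cn(-c2ccc(O)cc2)nc1-c1ccc(O)c(O)c1` gives only a limit of the assay, > 100000 nM.
Compound 3 `O=C(O)/C=C/c1cn(-c2ccc(O)cc2)nc1-c1cc(O)ccc1O` also gives only a limit of the assay, > 100000 nM.

Compound 2 and compound 3 share the same atoms, joined differently: 2,5-dihydroxyphenyl in place of 3,4-dihydroxyphenyl on an aromatic carbon. The resulting step, a step that the two limits leave unreadable from compound 2 to compound 3, cannot be sized due to the limit of > 100000 nM in this assay, at which 2 of the 3 values shown sit. From compound 2 to compound 1 the change is formyl in place of 2-carboxyethenyl on an aromatic carbon, and it gave an at least 8.3-fold lower number from compound 2 to compound 1 (0.92 log units; beyond the scatter).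

Compound 4 `O=Cc1cn(-c2ccc(O)cc2)nc1-c1cc(O)ccc1O` is not yet measured. It arises from compound 3 by the same kind of change, (formyl in place of 2-carboxyethenyl on an aromatic carbon), though here the group sits next to the ring atom that bears a 2,5-dihydroxyphenyl group rather than a 3,4-dihydroxyphenyl group. The step expected from compound 3 to compound 4 is an at least 4.0-fold lower number from compound 3 to compound 4 (0.60 log units; beyond the scatter), resting on an at least 8.3-fold lower number from compound 2 to compound 1 (0.92 log units; beyond the scatter). Compound 4 is therefore expected to give about 25000 nM, between 6000 nM and 100000 nM.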

Compound 4, half-maximal inhibitory concentration: 43000 nM
For compound 4 the middle estimate is 1.7-fold (0.24 log units) below the measured one, within the range that was stated.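

In this assay, putting formyl in place of 2-carboxyethenyl again lowers the number, with an at least 2.3-fold lower number from compound 3 to compound 4 (0.36 log units; beyond the scatter), so the direction of the change carries over from the core of compound 2 to the core of compound 3. This does not show that the change has the same size on both cores: the same change on two cores in this assay, an at least 8.3-fold lower number (0.92 log units; beyond the scatter) from compound 2 to compound 1 and an at least 2.3-fold lower number (0.36 log units; beyond the scatter) from compound 3 to compound 4; the limit leaves it open whether they differ. As far as these compounds go, the full size of each step also stays unknown because compound 2 and compound 3 each give only a limit of the assay: the limit of > 100000 nM in this assay, at which 2 of the 4 values shown sit.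

The compounds shown leave open whether the gain comes from formyl itself or from the loss of the longer chain. They also do not show how an amine or a hydroxymethyl group would behave in the same place on either core.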